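Replacing the cyanophenyl ether with a pyrazolylethyl ether

The source may hold more compounds than are shown below. What is called first, only, known or untested is meant among the compounds shown, and "the series" means these compounds.

Compound 3 `Cc1nn(-c2ncnc3nc[nH]c23)c2c1C(OCc1ccc(C#N)cc1)CC(=O)N2` carries the lowest of the three numbers in a functional assay on HEK293 cells for agonist activity at G-protein coupled receptor 39 (Homo sapiens), read by scintillation proximity assay and inositol phosphate accumulation, with a stated time of 75 min (on this read-out higher numbers stand for an effect only at larger amounts of compound and lower numbers for an effect already at smaller amounts), where compound 3 gives 60 nM. Compound 1 `Cc1nn(-c2ncnc3nc[nH]c23)c2c1C(OC1CCCC1)CC(=O)N2` gives 62 nM in this assay, and the step of a 1.0-fold lower number from compound 1 to compound 3 (0.01 log units; within the scatter) stays within the scatter, so the two cannot be ordered. For the measured compounds named here, compound 2 `CCCCCCCCOC1CC(=O)Nc2c1c(C)nn2-c1ncnc2nc[nH]c12` gives 388 nM, and the steps of a 6.3-fold higher number from compound 1 to compound 2 (0.80 log units; beyond the scatter) and a 6.5-fold lower number from compound 2 to compound 3 (0.81 log units; beyond the scatter) are the only changes beyond the scatter among the measured compounds. Compound 4 `Cc1nn(-c2ncnc3nc[nH]c23)c2c1C(OCCn1cccn1)CC(=O)N2` is unmeasured. It differs from compound 3 in one place: (1H-pyrazol-1-yl)methyl in place of 4-cyanophenyl on a saturated chain carbon bound to an oxygen on a saturated carbon. Going by the values given here, no measured step exchanges an aromatic group for a different heteroaromatic one at this position; the step from compound 2 to compound 3 shows that the group on the oxygen can matter, while the step from compound 1 to compound 3 shows a carbocycle and a cyanobenzyl group giving the same number. Given this, compound 4 is expected to remain close to compound 3, with the step of a 2.0-fold higher number from compound 3 to compound 4 (0.30 log units; within the scatter) estimated as small or within the scatter. Compound 4 is therefore expected at about 120 nM, in a range from 40 nM to 400 nM.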

Compound 4, half-maximal effective concentration: 2270 nM
Beside the measured number, compound 4's estimate is 19-fold (1.28 log units) below it; the measured number lies above the stated range.
By their numbers in this assay, from the lowest: compounds 3 and 1 (each within the scatter of the next); then compound 2; then compound 4.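

For the compounds shown here, at the group on the oxygen on a saturated carbon, 2-(1H-pyrazol-1-yl)ethyl is the first change to give a large step in this assay, with a 38-fold higher number from compound 3 to compound 4 (1.58 log units; beyond the scatter) and a 37-fold higher number from compound 1 to compound 4 (1.56 log units; beyond the scatter). It also goes beyond the long open chain, with a 5.9-fold higher number from compound 2 to compound 4 (0.77 log units; beyond the scatter), so an aromatic ring in this group does not by itself keep the number low, as compound 3 and compound 4 both carry one. Nothing available bears on why this change has so large an effect.

The compounds shown leave open whether the step goes with the pyrazole ring or with its ethyl link, as the two change together between compound 3 and compound 4. They also do not show how a 2-phenylethyl group or a 2-(dimethylamino)ethyl group would read at this position.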